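Replacing an oxadiazole with phenyl on the piperidine nitrogen

The compounds below may be only part of what the source reports. "The series", "measured", "known", "first", "only" and "open" are said of these compounds alone.

Compound 3 `Cc1nnc(N2CCC(C(=O)N3N=CC[C@H]3c3ccccc3)CC2)o1` gives 3.2 in a physicochemical assay for lipophilicity, read by HPLC, measured as chromatographic lipophilicity, at pH 7.4 (a lower number here means a more polar compound, a higher number a more lipophilic compound), the second highest of three numbers. Compound 1 `CC(=O)N1CCC(C(=O)N2N=CC[C@H]2c2ccccc2)CC1` gives 2.5, with the step of a number 0.70 log units higher from compound 1 to compound 3 (beyond the scatter). Compound 2 `O=C(C1CCN(c2ccccn2)CC1)N1N=CC[C@H]1c1ccccc1` gives 5.1, with the steps of a number 2.60 log units higher from compound 1 to compound 2 (beyond the scatter) and a number 1.90 log units lower from compound 2 to compound 3 (beyond the scatter). Compound 4 `O=C(C1CCN(c2ccccc2)CC1)N1N=CC[C@H]1c1ccccc1` carries the change (phenyl in place of 5-methyl-1,3,4-oxadiazol-2-yl on an amine nitrogen in a ring). The step from compound 2 to compound 3 bears most directly on it, since it swaps one six-membered aromatic ring on that nitrogen for the oxadiazole, and it was large. The reverse direction is therefore expected here, a large rise, and compound 4 is expected to give 5.6 in this assay, between 5 and 6.2, an expected step of a number 2.40 log units higher from compound 3 to compound 4 (beyond the scatter).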

Compound 4, distribution coefficient: 6.3
Compound 4: middle estimate off by 0.70 log units, on the low side; the whole stated range lies below it.
By their numbers in this assay, from the lowest: compound 1; then compound 3; then compound 2; then compound 4.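

In this assay, phenyl gives the highest number of the four groups on this amine nitrogen, with a number 3.10 log units higher from compound 3 to compound 4 (beyond the scatter) and a number 3.80 log units higher from compound 1 to compound 4 (beyond the scatter) on the same core. The earlier compounds shown here did not show that the two six-membered aromatic rings differ at this position, yet a number 1.20 log units higher from compound 2 to compound 4 (beyond the scatter) separates phenyl from pyridin-2-yl. No measured evidence here bears on the cause of these steps. Left open is where a methyl group or a cyclohexyl ring on this nitrogen would fall in this assay relative to these four compounds.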